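Trimming ethyl(methyl)amino to dimethylamino at a sensitive place

A few compounds are considered here, and "the series" means these few. Any claim that something is new, unique, unknown or untested is made for them only; others in the source may bear on it.

Going by the values given here, in a functional assay on PC-3 cells (Homo sapiens) for antiproliferative activity, with a stated time of 72 h (a lower number here means a stronger inhibitor, a higher number a weaker inhibitor), compound 3 (`CCN(C)Cc1c(OC)cc(OC)c(C(=O)/C=C/c2ccccc2Cl)c1O`) gives 3 nM, the lowest of the three numbers so far. Compound 1 (`COC(=O)CN(C)Cc1c(OC)cc(OC)c(C(=O)/C=C/c2ccccc2Cl)c1O`) gives 7200 nM, and compound 2 (`COc1cc(O)c2c(=O)cc(-c3ccccc3Cl)oc2c1CN1CCCCC1`) gives 63400 nM. Among the compounds with values here, compound 2 is joined to the others by no single-place step, so it says little about the change considered here.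

The next compound, compound 4 (`COc1cc(OC)c(C(=O)/C=C/c2ccccc2Cl)c(O)c1CN(C)C`), carries dimethylamino where compound 3 carries ethyl(methyl)amino: hydrogen in place of methyl on a saturated chain carbon bound to an amine nitrogen.

Within the data shown here, only one measured step touches this same place, and it is large: a 2400-fold lower number from compound 1 to compound 3 (3.38 log units; beyond the scatter), with methyl in place of methoxycarbonyl. That step shows that the number can move a long way with a change on this carbon. It is, however, a different exchange, and the data hold no direct measure of hydrogen replacing methyl. With compound 3 at 3 nM, at the low end of the numbers, a move upward seems more likely than a further drop, though probably far smaller than the step from methoxycarbonyl. The expected step is a 10-fold higher number from compound 3 to compound 4 (1.00 log units; beyond the scatter), with wide uncertainty. Compound 4 is estimated at 30 nM, with an expected range from 2 nM to 3000 nM.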

Compound 4, half-maximal inhibitory concentration: 400 nM
Beside the measured number, compound 4's estimate is 13-fold (1.12 log units) below it, within the range that was stated.
By their numbers in this assay, from the lowest: compound 3; then compound 4; then compound 1; then compound 2.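

In this assay, going by these compounds alone, the step of a 130-fold higher number from compound 3 to compound 4 (2.12 log units; beyond the scatter) is the first direct measure of hydrogen in place of methyl on a saturated chain carbon bound to an amine nitrogen, and it shows that this position responds strongly even to the loss of a single carbon. Set against a 2400-fold lower number from compound 1 to compound 3 (3.38 log units; beyond the scatter), and with an 18-fold lower number from compound 1 to compound 4 (1.26 log units; beyond the scatter) completing the set, it places the three compounds that differ at this carbon in a clear order: methyl gives the lowest number, hydrogen the next, and methoxycarbonyl the highest. Most of the gap between compound 1 and compound 3 therefore lies in the exchange of hydrogen for methyl, so ethyl(methyl)amino is much the better of the two small amines here. No measurement offered here explains why one carbon counts for so much.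

The compounds shown leave open whether a longer chain, such as propyl or butyl, would lower the number further or whether ethyl is already the best length. They also leave open how a carboxylic acid or a hydroxyethyl chain would fare on this same carbon.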